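Heteroaryl amide replacement on the carbonyl carbon: outlook for compound 3

The compounds below may be only part of what the source reports. "The series", "measured", "known", "first", "only" and "open" are said of these compounds alone.

Measured so far:
compound 1 `Cc1ccc2[nH]c(C(=O)N[C@H]3CN(S(=O)(=O)c4ccccc4)C[C@@H]3C(=O)N[C@H]3CCCNC3)cc2c1`: 98%
compound 2 `O=C(N[C@H]1CN(S(=O)(=O)c2ccccc2)C[C@@H]1C(=O)N[C@H]1CCCNC1)c1cc(C2CC2)n[nH]1`: 81%

In a functional assay on HEK293 cells for agonist activity at growth hormone secretagogue receptor type 1 (Homo sapiens), read by HTRF and inositol phosphate accumulation, with a stated time of 90 min, in the presence of a further agent that is not named here (a lower number here means a smaller maximal response, a higher number a larger maximal response), compound 1 reaches a response near the reference. Among the measured compounds shown here, compound 2 stands lowest of the two numbers measured, with compound 1 as its only neighbour; the single measured step, a number 17 percentage points lower from compound 1 to compound 2 (beyond the scatter), lies beyond the scatter but is modest in size.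

Compound 3 `O=C(N[C@H]1CN(S(=O)(=O)c2ccccc2)C[C@@H]1C(=O)N[C@H]1CCCNC1)c1cc(-c2ccccc2)on1` is not yet measured. The change from compound 2 to compound 3 is 5-phenyl-1,2-oxazol-3-yl in place of 3-cyclopropyl-1H-pyrazol-5-yl on a carbonyl carbon. For the measured compounds named here, the only step that bears on this place is a number 17 percentage points lower from compound 1 to compound 2 (beyond the scatter), where an exchange of the group on the same carbonyl carbon moved the maximal response downward by a modest amount. Two compounds give no rule for the direction of a further exchange; the data only show that both substituents measured so far leave the maximal response high. A change of similar or smaller size, in either direction, is therefore the expectation for compound 3, with the step from compound 2 estimated as a number 1 percentage points higher from compound 2 to compound 3 (within the scatter). For compound 3 the expected value is 82%, with a range from 62% to 100%.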

Compound 3, largest response reached (Emax), in percent of the reference or control that the assay uses: 90%
For compound 3 the middle estimate is 8 percentage points below the measured one; the measured number falls inside the stated range.
By their numbers in this assay, from the lowest: compounds 2, 3 and 1 (each within the scatter of the next, the first and the last beyond it).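

In this assay, the exchange at this place gives a number 9 percentage points higher from compound 2 to compound 3 (within the scatter), and the other comparison gives a number 8 percentage points lower from compound 1 to compound 3 (within the scatter), so the 5-phenyl-1,2-oxazol-3-yl group cannot be separated from either earlier group, although compound 1 and compound 2 differ beyond the scatter. The entering group has 0 hydrogen-bond donors, where 3-cyclopropyl-1H-pyrazol-5-yl has 1, and compound 3 still reaches 90%, so among these compounds a high maximal response on this carbonyl carbon does not depend on a hydrogen-bond donor in the group. No measurement offered here explains why the response stays at this level with these groups.

The compounds shown all carry an aromatic group with a five-membered ring on this carbonyl carbon, so it remains open whether the response holds with a non-aromatic group such as a butyl chain, or with a carboxylic acid or an amine added to the phenyl ring of compound 3. Going by these compounds, it also remains open how these groups compare on anything other than the largest response reached, and whether the same tolerance holds when the rest of the shared core is changed.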